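A few compounds are considered here, and "the series" means these few. Any claim that something is new, unique, unknown or untested is made for them only; others in the source may bear on it.

Measured in an ADME assay on L6 cells (Rattus norvegicus) for cytotoxicity, read by resazurin assay, with a stated time of 72 h; a lower number here means that less compound is needed, a higher number that more compound is needed for the effect:
- compound 1 `CCOC(=O)C1=C(C)N/C(=C/c2cc(C)n(-c3ccc(Br)cc3)c2C)C1=O`: 100000 nM
- compound 2 `CCOC(=O)C1=C(C)N/C(=C/c2cc(C)n(-c3cccnc3)c2C)C1=O`: 160000 nM
- compound 3 `CCOC(=O)C1=C(C)N/C(=C/c2cc(C)n(Cc3ccc(C(F)(F)F)cc3)c2C)C1=O`: 72000 nM

Compound 1 stands second highest of the three numbers. Its nearest neighbour is compound 3, whose value sits within the scatter of that of compound 1; compound 2 lies furthest away, and the step of a 1.6-fold higher number from compound 1 to compound 2 (0.20 log units; within the scatter) is also within the scatter. So the three measured compounds are not separated in this assay.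

Compound 4 `CCOC(=O)C1=C(C)N/C(=C/c2cc(C)n(Cc3ccccc3)c2C)C1=O` has not yet been measured in this assay. It differs from compound 1 as follows: benzyl in place of 4-bromophenyl on an aromatic nitrogen. Among the measured compounds shown here, the one measured step that touches the same place, a 1.6-fold higher number from compound 1 to compound 2 (0.20 log units; within the scatter), did not move the number beyond the scatter. Compound 3, which also carries a benzyl-type group on that nitrogen, shows a value within the scatter of compound 1. For the measured compounds named here, no step among the measured compounds suggests a shift beyond the scatter for this kind of change, so no step beyond the scatter is expected here.

Compound 4 is therefore estimated at 85000 nM in this assay, with a range of 45000 nM to 160000 nM. The expected step is a 1.2-fold lower number from compound 1 to compound 4 (0.07 log units; within the scatter).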

Compound 4, half-maximal effective concentration: 50000 nM
Estimate against measurement, compound 4: 1.7-fold (0.23 log units) above, within the range that was stated.
By their numbers in this assay, from the lowest: compounds 4, 3, 1 and 2 (each within the scatter of the next, the first and the last beyond it).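

In this assay, among the compounds shown here, the group on the aromatic nitrogen now gives the only step beyond the scatter, a modest one between pyridin-3-yl and benzyl (a 3.2-fold lower number from compound 2 to compound 4 (0.51 log units; beyond the scatter)). Benzyl in place of 4-bromophenyl remains within the scatter (a 2.0-fold lower number from compound 1 to compound 4 (0.30 log units; within the scatter)), as does hydrogen in place of trifluoromethyl on an aromatic carbon (a 1.4-fold lower number from compound 3 to compound 4 (0.16 log units; within the scatter)), so neither change separates its pair. For the compounds shown here, no supporting measurement is available to explain the one step beyond the scatter.

From the compounds shown here alone, all four compounds carry a six-membered aromatic ring on that nitrogen, or a benzyl-type group, so it remains open how a simple alkyl chain or a longer chain ending in an amine would read there. Going by these compounds, whether a carboxylic acid in place of trifluoromethyl would give a step beyond the scatter is also open.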